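This account rests on a few compounds, and the source may have more. Where it says the series, first, only, none or still open, it means among the compounds named here.

Values in a functional assay on MDA-MB-231 cells (Homo sapiens) for inhibition, read by MTT assay, with a stated time of 72 h; a lower number here means a stronger inhibitor, a higher number a weaker inhibitor; each one is a limit and not a number:
- Compound 1 `CC(C)(C)n1cc2c(n1)C(=O)CC1(CCN(C(=O)c3cc(-c4ccc(Cl)cc4)nc4ccccc34)CC1)O2`: > 10000 nM
- Compound 2 `CC(C)(C)n1cc2c(n1)C(=O)CC1(CCN(C(=O)c3cc(-c4ccc(Br)cc4)nc4ccccc34)CC1)O2`: > 10000 nM
- Compound 3 `CN(C)c1ccc(-c2cc(C(=O)N3CCC4(CC3)CC(=O)c3nn(C(C)(C)C)cc3O4)c3ccccc3n2)cc1`: > 10000 nM

Compound 3 has no number that would place it in the series, and the three compounds share one reading: the limit of > 10000 nM in this assay, at which 3 of the 3 values shown sit.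

Compound 4 `CC(C)(C)n1cc2c(n1)C(=O)CC1(CCN(C(=O)c3cc(Cl)nc4ccccc34)CC1)O2` carries chloro in place of 4-(dimethylamino)phenyl on an aromatic carbon next to the ring nitrogen (chloro in place of 4-(dimethylamino)phenyl on an aromatic carbon).

The measured steps give no size to carry over: a step that the two limits leave unreadable from compound 1 to compound 2, a step that the two limits leave unreadable from compound 1 to compound 3 and a step that the two limits leave unreadable from compound 2 to compound 3. All three keep the aromatic ring that leaves here.

The expectation rests on compound 3 at its limit of > 10000 nM. No direction can be drawn from this, and the estimated change is a step that the limit leaves unreadable from compound 3 to compound 4. The estimate for compound 4 is 12000 nM, with an expected range from 3000 nM to 40000 nM.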

Compound 4, half-maximal inhibitory concentration: 9220 nM
Beside the measured number, compound 4's estimate is 1.3-fold (0.11 log units) above it, within the range that was stated.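

In this assay, chloro at this position, next to the ring nitrogen, gives compound 4 the only actual number among the compounds shown, 9220 nM. Against the phenyl-bearing compounds, the steps are an at least 1.0-fold lower number from compound 3 to compound 4 (0.03 log units; that floor lies within the scatter), an at least 1.0-fold lower number from compound 2 to compound 4 (0.03 log units; that floor lies within the scatter) and an at least 1.0-fold lower number from compound 1 to compound 4 (0.03 log units; that floor lies within the scatter). Each is only a floor, so the true size of the change stays unread, and the series still sits at or close to one ceiling: the limit of > 10000 nM in this assay, at which 3 of the 4 values shown sit.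

Open, as far as these compounds go, is how an amine, a methoxy group or a methyl group would read at this position. Also open, from the compounds shown here alone, is whether any group placed here moves the number beyond the scatter.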